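Swapping Phenethyl for Cyclohexyl on a Shared Core

This account rests on a few compounds, and the source may have more. Where it says the series, first, only, none or still open, it means among the compounds named here.

Measured in an ADME assay on HepG2 cells (Homo sapiens) for cytotoxicity, read by luminescence, CellTiter-Glo and ATP content, with a stated time of 72 h; a higher number here means that more compound is needed for the effect, a lower number that less compound is needed:
- compound 1 `CC(C)Cc1ccc2c(NCCCNCc3ccco3)ccnc2c1` gives 16000 nM
- compound 2 `COc1ccc(F)cc1CNCCCNc1ccnc2cc(C3CCCCC3)ccc12` gives 2290 nM
- compound 3 `c1ccc(CCc2ccc3c(NCCCNCc4ccco4)ccnc3c2)cc1` gives 16000 nM

Compound 3 stands level with compound 1, and the two together hold the highest numbers of the three; compound 2, which carries a cyclohexyl and a different benzyl on the amine, gives a lower number, beyond the scatter.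

Compound 4 `c1coc(CNCCCNc2ccnc3cc(C4CCCCC4)ccc23)c1` differs from compound 3 in one place: cyclohexyl in place of phenethyl on an aromatic carbon. Among the compounds with values here, one measured step touches this position: no change at the digits printed from compound 1 to compound 3 (within the scatter), which shows that exchanging groups there can leave this assay unmoved. Compound 2 also carries the cyclohexyl, yet it differs from compound 4 at the amine as well, so its value only hints that a cyclohexyl-bearing compound can sit lower.

Weighing both, a modest downward step is expected, a 2.0-fold lower number from compound 3 to compound 4 (0.30 log units; within the scatter). Compound 4 is therefore estimated at 8000 nM, with a range from 3000 nM to 20000 nM.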

Compound 4, half-maximal effective concentration: 4760 nM
For compound 4 the middle estimate is 1.7-fold (0.23 log units) above the measured one; the measured number falls inside the stated range.
By their numbers in this assay, from the lowest: compound 2; then compound 4; then compounds 1 and 3 (each within the scatter of the next).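

In this assay the group on this aromatic carbon can matter after all: cyclohexyl in place of phenethyl gives a 3.4-fold lower number from compound 3 to compound 4 (0.53 log units; beyond the scatter) and cyclohexyl in place of isobutyl gives a 3.4-fold lower number from compound 1 to compound 4 (0.53 log units; beyond the scatter) with the amine side held fixed. The amine side moves the number too, as furan-2-yl in place of 5-fluoro-2-methoxyphenyl gives a 2.1-fold higher number from compound 2 to compound 4 (0.32 log units; beyond the scatter) with cyclohexyl held fixed. Nothing measured here explains these shifts.

Still open, from the compounds shown here alone, is how a small methyl, or a cyclohexyl carrying an amine or a carboxylic acid, would behave on this carbon.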